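A Changed Amide Ring and Its Expected Binding

The source may report more compounds than this note shows. Statements on the series, on what has been measured and on what is new or still open speak of the compounds shown alone.

Compound 1, `Cc1cc(C(=O)Nc2ccc(F)cc2)nn1-c1cccc(C(F)(F)F)c1`, gives 800 nM in an assay on HEK293 cells for binding affinity to Neuropeptide Y receptor type 5 (Homo sapiens), read by radioligand binding; on this read-out lower numbers stand for stronger inhibition and higher numbers for weaker inhibition.
Compound 2, `Cc1cc(C(=O)Nc2cc(Cl)cc(Cl)c2)nn1Cc1ccccc1`, gives only a limit of > 1000 nM in this assay.

Compound 1 thus stands as the only numeric result in this assay; the other result is a limit, (the limit of > 1000 nM in this assay, at which 1 of the 2 values shown sits). Compound 3, `Cc1ccccc1NC(=O)c1cc(C)n(-c2cccc(C(F)(F)F)c2)n1`, is not yet measured. It differs from compound 1 by 2-methylphenyl in place of 4-fluorophenyl on an amide-type nitrogen. Among the measured compounds shown here, no step between measured compounds is available, so the size of this change in this assay cannot be read from what is known. The expected step is a 1.5-fold higher number from compound 1 to compound 3 (0.18 log units; within the scatter), within the scatter or leaning toward weaker binding. For compound 3 the estimate is 1200 nM, with a range from 400 nM to 4000 nM.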

Compound 3, half-maximal inhibitory concentration: 573 nM
Compound 3: the middle estimate sits 2.1-fold (0.32 log units) above what was measured, within the range that was stated.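

In this assay, placing 2-methylphenyl instead of 4-fluorophenyl on the amide-type nitrogen gives a 1.4-fold lower number from compound 1 to compound 3 (0.14 log units; within the scatter), so this exchange leaves the binding number within the scatter. Among the compounds shown here, this is the first step that can be read at this place, and it shows that these two rings cannot be told apart in this measurement. None of the evidence available accounts for this result. From the compounds shown here alone, whether a plain phenyl, a cyclohexyl group or a longer chain on this nitrogen would give a step beyond the scatter remains open. A single pair also cannot show how far this result extends to other groups.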